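Nitro on the benzyl arm of compound 3

The source may report more compounds than this note shows. Statements on the series, on what has been measured and on what is new or still open speak of the compounds shown alone.

In an assay on cells for displacement of a labelled ligand from corticotropin-releasing factor receptor 1 (Homo sapiens), with a stated time of 100 min (on this read-out higher numbers stand for weaker inhibition and lower numbers for stronger inhibition), compound 3 `CCCN(Cc1ccccc1)Cc1c(C(F)(F)F)nc2n(-c3c(C)cc(C)cc3C)c(Cl)cn12` gives 170 nM, the highest of the three numbers in hand. Compound 2 `Cc1cc(C)c(-n2c(Cl)cn3c(CN(C)Cc4ccccc4)c(C(F)(F)F)nc23)c(C)c1` gives 160 nM, and the step of a 1.1-fold higher number from compound 2 to compound 3 (0.03 log units; within the scatter) lies within the scatter. Compound 1 `C=CCN(CCC)Cc1c(C(F)(F)F)nc2n(-c3c(C)cc(C)cc3C)c(Cl)cn12` gives 4.5 nM; the steps of a 36-fold higher number from compound 1 to compound 2 (1.55 log units; beyond the scatter) and a 38-fold higher number from compound 1 to compound 3 (1.58 log units; beyond the scatter) are both large.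

Compound 4 `CCCN(Cc1ccc([N+](=O)[O-])cc1)Cc1c(C(F)(F)F)nc2n(-c3c(C)cc(C)cc3C)c(Cl)cn12` differs from compound 3 by nitro in place of hydrogen on an aromatic carbon. Going by the values given here, no measured step touches the benzyl ring itself: the two large steps concern the exchange of the allyl(propyl)amino arm for a benzyl-bearing amine, and the small step concerns the alkyl group on the nitrogen. The series therefore gives no direct guide to a substituent on the aromatic ring, and the default expectation is a step no larger than the scatter.

For compound 4 the expected step is no change at the digits printed from compound 3 to compound 4 (within the scatter), with an estimate of 170 nM in this assay, between 60 nM and 500 nM.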

Compound 4, inhibition constant: 150 nM
For compound 4 the middle estimate is 1.1-fold (0.05 log units) above the measured one; low and high end bracket the measured number.
By their numbers in this assay, from the lowest: compound 1; then compounds 4, 2 and 3 (each within the scatter of the next).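

With 4-nitrobenzyl in place of benzyl, this assay gives a 1.1-fold lower number from compound 3 to compound 4 (0.05 log units; within the scatter) and so puts this first substituent on the ring, para to a large group, within the scatter of the unsubstituted benzyl arm. The gap to the allyl(propyl)amino arm remains large at a 33-fold higher number from compound 1 to compound 4 (1.52 log units; beyond the scatter) in the same read-out, so nitro at this place does not bring the benzyl series near compound 1. No data at hand offer an explanation for this result.

A single group at a single ring position cannot show whether the ring is insensitive to substitution in general. Open questions are whether an amine, a carboxylic acid or a methoxy group at this place would also stay within the scatter of compound 3, and whether any ring substituent could narrow the large gap to compound 1.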